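Chloromethylbenzyl purines: amino substitution across two benzyl isomers

The source may report more compounds than this note shows. Statements on the series, on what has been measured and on what is new or still open speak of the compounds shown alone.

Compound 1 `ClCc1ccc(Cn2cnc3c(Cl)ncnc32)cc1` carries the chloromethyl group on one benzyl pattern; in a functional assay on SK-OV-3 cells (Homo sapiens) for cytotoxicity, read by sulforhodamine B assay, with a stated time of 48 h (a lower number here means a stronger inhibitor of growth, a higher number a weaker inhibitor of growth), compound 1 gives 13800 nM. Compound 2 `Nc1nc(Cl)c2ncn(Cc3ccc(CCl)cc3)c2n1` is its amino analogue, differing by amino in place of hydrogen on an aromatic carbon, and in this assay compound 2 gives 30900 nM. Going by the values given here, the step of a 2.2-fold higher number from compound 1 to compound 2 (0.35 log units; beyond the scatter) is the only measured example of this change in the set.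

Compound 3 `ClCc1ccccc1Cn1cnc2c(Cl)ncnc21` has the same atoms as compound 1 joined differently; the difference between the two cores is not broken down here. In this assay compound 3 gives 15900 nM, and the gap between compound 3 and compound 1, as between compound 3 and compound 2, falls within the usual scatter, so no order among these three is claimed.

Compound 4 `Nc1nc(Cl)c2ncn(Cc3ccccc3CCl)c2n1` stands to compound 3 as compound 2 stands to compound 1: it differs by amino in place of hydrogen on an aromatic carbon, and the place of the change matches that of the earlier pair word for word, so this is the same change on the other benzyl core. Among the compounds with values here, with only one measured example, the expectation rests on that single step: the change from compound 3 to compound 4 is expected to show a step of about a 2.1-fold higher number from compound 3 to compound 4 (0.32 log units; beyond the scatter) in this assay, because the earlier pair gave a 2.2-fold higher number from compound 1 to compound 2 (0.35 log units; beyond the scatter). On that basis compound 4 is estimated at 33000 nM in this assay, with a range from 14000 nM to 80000 nM allowing for the fact that a single precedent carries its own scatter.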

Compound 4, concentration for total growth inhibition: 52500 nM
The estimate for compound 4 lay 1.6-fold (0.20 log units) below the measured number; the range from low to high includes it.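

In this assay, amino in place of hydrogen on an aromatic carbon raises the number on the second benzyl core as it did on the first, with a 3.3-fold higher number from compound 3 to compound 4 (0.52 log units; beyond the scatter). Set beside the earlier pair, the size of the step carries over from one core to the other, with no difference between the two that can be told from the scatter: the same change on two cores in this assay, a 2.2-fold higher number (0.35 log units; beyond the scatter) from compound 1 to compound 2 and a 3.3-fold higher number (0.52 log units; beyond the scatter) from compound 3 to compound 4, 1.5-fold (0.17 log units) apart, within the scatter of two such steps This shows only that the change gave a weaker inhibitor of growth on both of these cores, in this one assay; two pairs establish no general rule for the series, do not show that the core alters the size of the step, and give no reason for the step.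

Still open, on these data alone, is whether a methylamino or hydroxyl group on the same aromatic carbon, between the two ring nitrogen atoms, would shift the number as amino does, or whether the shift is particular to amino. Also open is whether the step would persist on a core carrying bromomethyl or hydroxymethyl in place of the chloromethyl group, since every pair shown keeps chloromethyl.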